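Ester variation in a hydroxy-ester series: toward compound 4

The source may report more compounds than this note shows. Statements on the series, on what has been measured and on what is new or still open speak of the compounds shown alone.

Measured so far:
compound 1 `CC(C)OC(=O)C(O)Cn1cnc2c(N)ncnc21` — in a functional assay on Vero cells (Chlorocebus sabaeus) for cytotoxicity (on this read-out lower numbers stand for higher toxicity in this test and higher numbers for lower toxicity in this test), compound 1 gives > 400 ug/mL, a limit of the test and not a number.
compound 2 `CC(C)CCOC(=O)C(O)Cn1cnc2c(N)ncnc21` — in this assay compound 2 gives 400 ug/mL.
compound 3 `Nc1ncnc2c1ncn2CC(O)C(=O)OCc1ccco1` — in this assay compound 3 gives 40 ug/mL.

Compound 3 stands lowest of the numbers shown. Going to it from either alkyl ester the number drops: a 10-fold lower number from compound 2 to compound 3 (1.00 log units; beyond the scatter) and an at least 10-fold lower number from compound 1 to compound 3 (1.00 log units; beyond the scatter). Between the two alkyl esters themselves the picture is a number no higher from compound 1 to compound 2 (the limit leaves the size open).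

Compound 4 `CCC(C)OC(=O)C(O)Cn1cnc2c(N)ncnc21` has not yet been measured in this assay. (sec-butyl in place of (furan-2-yl)methyl on an oxygen next to a carbonyl group). This change runs the two measured steps backwards in kind, putting a plain alkyl group on the oxygen next to a carbonyl group where compound 3 carries the furan-bearing one, so a rise of about the size seen in a 10-fold lower number from compound 2 to compound 3 (1.00 log units; beyond the scatter) is expected, that is a 10-fold higher number from compound 3 to compound 4 (1.00 log units; beyond the scatter). Compound 4 is therefore estimated at 400 ug/mL, within 200 ug/mL to 800 ug/mL, with a fair chance that only a limit is reported.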

Compound 4, minimum cytotoxic concentration: > 400 ug/mL
Compound 4 was reported as a limit; the forecaster's own chance of this, stated with the estimate: 40%; the middle value lies on the limit itself.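

Going by these compounds alone, the change to sec-butyl gives an at least 10-fold higher number from compound 3 to compound 4 (1.00 log units; beyond the scatter) in this assay, so a third alkyl ester sits high on the scale and compound 3, with (furan-2-yl)methyl, remains the only low value. Replacing isopentyl gives a number no lower from compound 2 to compound 4 (the limit leaves the size open), with compound 4 reported as a limit. The steps among the limit values cannot be read, because compound 1 and compound 4 are both limits: the limit of > 400 ug/mL in this assay, at which 2 of the 4 values shown sit.

As far as these compounds go, whether the low value belongs to the furan ring or to any ring stays open. So does what a benzyl ester, a longer chain or a carboxylic acid would give.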